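Swapping a Carbamoyl for a Hydroxyethyl on the Triazole Chain

A few compounds are considered here, and "the series" means these few. Any claim that something is new, unique, unknown or untested is made for them only; others in the source may bear on it.

Compound 1 `Cc1cc(C)c(Oc2cc(Nc3ccc(C#N)cc3)ncc2C(=O)NCc2cn(CC(N)=O)nn2)c(C)c1` was examined in an ADME assay on MT4 cells (Homo sapiens) for cytotoxicity, read by MTT assay, with a stated time of 5 days (a higher number here means that more compound is tolerated, a lower number that less compound is tolerated), where compound 1 gives 24000 nM. Two close relatives differ from it only at the chain attached to the triazole ring. Compound 2 `COC(=O)Cn1cc(CNC(=O)c2cnc(Nc3ccc(C#N)cc3)cc2Oc2c(C)cc(C)cc2C)nn1` gives 13800 nM, and compound 3 `Cc1cc(C)c(Oc2cc(Nc3ccc(C#N)cc3)ncc2C(=O)NCc2cn(CCC#N)nn2)c(C)c1` gives 40200 nM. Among the measured compounds shown here, the step of a 1.7-fold lower number from compound 1 to compound 2 (0.24 log units; within the scatter) and the step of a 1.7-fold higher number from compound 1 to compound 3 (0.22 log units; within the scatter) both keep compound 1 indistinguishable from its neighbours, so the three values cannot be put in a firm order; only the step of a 2.9-fold higher number from compound 2 to compound 3 (0.46 log units; beyond the scatter) reaches beyond the scatter. The new compound 4 `Cc1cc(C)c(Oc2cc(Nc3ccc(C#N)cc3)ncc2C(=O)NCc2cn(CCCO)nn2)c(C)c1` differs from compound 1 by 2-hydroxyethyl in place of carbamoyl on a saturated chain carbon bound to an aromatic nitrogen. The measured step that bears most directly on this change is a 1.7-fold higher number from compound 1 to compound 3 (0.22 log units; within the scatter), where another replacement of the carbamoyl group at the same place left the number within the scatter. On that basis no shift beyond the scatter is expected, and the estimate for compound 4 is 27000 nM, with a range from 12000 nM to 60000 nM, which corresponds to an expected step of a 1.1-fold higher number from compound 1 to compound 4 (0.05 log units; within the scatter).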

Compound 4, half-maximal cytotoxic concentration: 25200 nM
Compound 4: the middle estimate sits 1.1-fold (0.03 log units) above what was measured; measured number inside the range.
By their numbers in this assay, from the lowest: compounds 2, 1, 4 and 3 (each within the scatter of the next, the first and the last beyond it).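

Replacing carbamoyl with 2-hydroxyethyl on this chain gives a 1.1-fold higher number from compound 1 to compound 4 (0.02 log units; within the scatter) in this assay, so a third end group at this place also stays within the scatter of compound 1. Among the compounds shown here, the other two comparisons give a 1.6-fold lower number from compound 3 to compound 4 (0.20 log units; within the scatter) and a 1.8-fold higher number from compound 2 to compound 4 (0.26 log units; within the scatter), which places compound 4 within the scatter of both members of the only pair that lies beyond it, so compound 4 does not sharpen the order of the series. No measurement at hand offers an explanation for this result.

From the compounds shown here alone, it remains open whether a 3-aminopropyl chain, a chain ending in a carboxylic acid, or a longer chain would also stay within the scatter at this place. Going by these compounds, it also remains open whether moving from carbamoyl to 2-hydroxyethyl matters in any assay other than this assay.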